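A few compounds are considered here, and "the series" means these few. Any claim that something is new, unique, unknown or untested is made for them only; others in the source may bear on it.

Working notes on the series in an assay on isolated protein for binding affinity to corticotropin-releasing factor receptor 1 (Homo sapiens); on this read-out higher numbers stand for weaker inhibition and lower numbers for stronger inhibition. Compound 1 `Cc1cccc(C(Nc2ccc(C)cc2Cl)C(=O)CCc2ccncc2)c1` sits at the limit of the assay, giving > 10000 nM. Compound 2 `Cc1ccc(C(Nc2ccc(C)cc2Cl)C(=O)CCc2ccncc2)cc1` likewise returns only the limit > 10000 nM. The one-place step that the two limits leave unreadable from compound 1 to compound 2 is therefore unreadable. Compound 3 `Cc1ccc(NC(C(=O)CCc2ccccn2)c2ccccc2Br)c(Cl)c1` also gives only the limit > 10000 nM. Taken together the three measured values show no more than the limit of > 10000 nM in this assay, at which 3 of the 3 values shown sit, and no step among them can be read in size or direction.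

Compound 4 `Cc1ccc(NC(C(=O)CCc2ccc(F)cc2)c2ccccc2Br)c(Cl)c1` differs from compound 3 by 4-fluorophenyl in place of pyridin-2-yl on a saturated chain carbon, two bonds along the chain from a carbonyl carbon. Among the measured compounds shown here, no measured step bears on this change, and the only evidence at hand is the limit of > 10000 nM in this assay, at which 3 of the 3 values shown sit. Compound 4 is therefore expected to remain near the limit of this assay. The step of an at least 1.2-fold lower number from compound 3 to compound 4 (0.09 log units; that floor lies within the scatter) that this estimate implies is expected to carry no readable direction. In this assay compound 4 is estimated at 8000 nM, between 1500 nM and 30000 nM.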

Compound 4, inhibition constant: > 10000 nM
Compound 4: only a limit was reported; the forecaster's own chance of this, stated with the estimate: 70%; middle value at least 1.2-fold (0.09 log units) from the limit.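

In this assay compound 4 gives only the limit > 10000 nM, and the step from compound 3 to compound 4 cannot be read. The compounds shown leave open which structural features, if any, bring a value inside the measurable range.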